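The source may report more compounds than this note shows. Statements on the series, on what has been measured and on what is new or still open speak of the compounds shown alone.

Of the compounds shown here, three built on the same core have been tested in an assay on HOS cells for agonist activity at vitamin D3 receptor (Homo sapiens), read by a luciferase reporter; on this read-out higher numbers stand for an effect only at larger amounts of compound and lower numbers for an effect already at smaller amounts. Compound 1 `CCC(O)(CC)COc1ccc(C(CC)(CC)c2ccc(OC[C@@H](O)CO)c(C)c2)cc1C` gives 18 nM in this assay. Compound 2 `CCC(CC)(c1ccc(OCC(CO)CO)c(C)c1)c1ccc(OCC(C)(C)O)c(C)c1` gives 76.5 nM. Compound 3 `CCC(O)(CC)COc1ccc(C(CC)(CC)c2ccc(OCC(CO)CO)c(C)c2)cc1C` gives 9.26 nM, the lowest of the three numbers; its gap to compound 1 lies within the scatter, while its gap to compound 2 lies beyond it.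

Two steps lead to compound 3. The change a 1.9-fold lower number from compound 1 to compound 3 (0.29 log units; within the scatter) rearranges the diol chain on one aromatic oxygen and stays within the scatter. The change an 8.3-fold lower number from compound 2 to compound 3 (0.92 log units; beyond the scatter) enlarges the hydroxylated group on the other aromatic oxygen and is a modest step beyond the scatter.

Compound 4 `CCC(O)(CC)COc1ccc(C(CC)(CC)c2ccc(OC(CO)CO)c(C)c2)cc1C` differs from compound 3 in one place: 2-hydroxy-1-(hydroxymethyl)ethyl in place of 3-hydroxy-2-(hydroxymethyl)propyl on an oxygen on an aromatic ring. The chain on that oxygen loses one carbon, keeping both hydroxyl groups. For the measured compounds named here, the step most comparable to this is the one from compound 1 to compound 3, which also reshaped the diol chain on this oxygen and moved the number only within the scatter. For compound 4 a step of a 1.5-fold higher number from compound 3 to compound 4 (0.18 log units; within the scatter) is therefore expected, with no movement beyond the scatter. In this assay compound 4 is estimated at 14 nM, within a range of 5 nM to 40 nM.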

Compound 4, half-maximal effective concentration: 17.2 nM
Compound 4: middle estimate off by 1.2-fold (0.09 log units), on the low side; measured number inside the range.
By their numbers in this assay, from the lowest: compounds 3, 4 and 1 (each within the scatter of the next); then compound 2.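

The result adds a third chain on this aromatic oxygen: in this assay, the step of a 1.9-fold higher number from compound 3 to compound 4 (0.27 log units; within the scatter) and the step of a 1.0-fold lower number from compound 1 to compound 4 (0.02 log units; within the scatter) both stay within the scatter, so 2-hydroxy-1-(hydroxymethyl)ethyl cannot be told apart from either 3-hydroxy-2-(hydroxymethyl)propyl or 2,3-dihydroxypropyl. Until now only one reshaping of this chain could be read, whereas the three chains in compound 1, compound 3 and compound 4 now show that both a smaller chain and a different branching pattern leave the number within the scatter, provided the two hydroxyl groups stay in place. Nothing shown explains why these changes make so little difference in this assay, as no supporting measurement bears on the result.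

All the chains on this oxygen in the compounds shown carry two hydroxyl groups, so it remains open whether both are needed or whether a single hydroxyl group, as in 2-hydroxyethyl, would give a similar number. Going by these compounds, it is also open how far the tolerance extends, for instance to a carboxylic acid, an amine or a longer chain such as 4,5-dihydroxypentyl on the same oxygen.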